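Swapping Methoxy for Amino on the Benzyl Ring

The source may hold more compounds than are shown below. What is called first, only, known or untested is meant among the compounds shown, and "the series" means these compounds.

Measured compounds:
compound 1, `COC(=O)c1ccc(NCc2cncn2Cc2ccccc2N)cc1-c1ccccc1`: 25000 nM
compound 2, `COC(=O)c1ccc(NCc2cncn2Cc2ccc(OC)cc2)cc1-c1ccccc1`: "not determined" (no result reported)
compound 3, `COC(=O)c1ccc(NCc2cncn2Cc2cccc(OC)c2)cc1-c1ccccc1`: "not determined" (no result reported)

Compound 1 was tested in a toxicity assay on NIH3T3 cells (Mus musculus) for cytotoxicity, read by resazurin assay (a lower number here means that less compound is needed, a higher number that more compound is needed for the effect), and gave 25000 nM. Compound 2 and compound 3 share the same core and differ from compound 1 only in the group on the benzyl ring, yet for both of them no number was reported in this assay: compound 2 stands at "not determined" (no result reported) and compound 3 at "not determined" (no result reported). Compound 3 therefore stands without a value of its own, and the only numerical anchor in this series is compound 1.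

Compound 4, `COC(=O)c1ccc(NCc2cncn2Cc2cccc(N)c2)cc1-c1ccccc1`, is the next step from compound 3. The change is amino in place of methoxy on an aromatic carbon. Among the compounds with values here, since compound 3 has no value, no step can be sized from data; the expectation rests on compound 1, which carries an amino group on the same benzyl ring, and that anchor keeps the expectation close to it because compound 1 in this assay gives 25000 nM.

In this assay compound 4 is expected to give about 25000 nM, with a range estimated from 8000 nM to 80000 nM.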

Compound 4, half-maximal effective concentration: > 10000 nM
Compound 4 was reported as a limit; the forecaster's own chance of this, stated with the estimate: 30%; the middle value is on the limit's open side.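

In this assay compound 4 gives > 10000 nM, which is a limit and not a number. No step can be read from compound 1 to compound 4, and compound 3 offers no number to compare. On these data alone, what stays open is how far compound 4 truly lies from compound 1.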